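This account rests on a few compounds, and the source may have more. Where it says the series, first, only, none or still open, it means among the compounds named here.

Measured in a functional assay for inhibition, with Rattus norvegicus as the target; on this read-out lower numbers stand for stronger inhibition and higher numbers for weaker inhibition:
- compound 1 `C[C@H](/N=C(/S)Nc1ccncc1)C(C)(C)C`: 316 nM
- compound 2 `CC(C)(C)CN/C(=C\[N+](=O)[O-])Nc1ccncc1`: 10000 nM

Compound 2 holds the higher of the two numbers, which means the weaker inhibition. Compound 1 gives 316 nM and compound 2 gives 10000 nM, a gap beyond the usual scatter. These two compounds differ in more than one place, so no single change has yet been measured on its own.

Compound 3 `CC(N/C(=C\[N+](=O)[O-])Nc1ccncc1)C(C)(C)C` departs from compound 2 in one place: methyl in place of hydrogen on a saturated chain carbon bound to an amine nitrogen and a saturated chain carbon. A methyl takes the place of a hydrogen on a saturated chain carbon bound to an amine nitrogen and a saturated chain carbon, which turns neopentyl into 1,2,2-trimethylpropyl.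

The expectation in this assay is a moderate step towards stronger inhibition, beyond the scatter. It rests on compound 1, which carries the 1,2,2-trimethylpropyl chain and gives 316 nM. The evidence is thin, as the rest of that molecule is different. The expected change is a 6.7-fold lower number from compound 2 to compound 3 (0.82 log units; beyond the scatter). For compound 3 the estimate is 1500 nM, with an expected range from 300 nM to 10000 nM.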

Compound 3, half-maximal inhibitory concentration: 1000 nM
Compound 3: the middle estimate sits 1.5-fold (0.18 log units) above what was measured; the range from low to high includes it.
By their numbers in this assay, from the lowest: compound 1; then compound 3; then compound 2.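

For the compounds shown here, the step of a 10-fold lower number from compound 2 to compound 3 (1.00 log units; beyond the scatter) is the first single change that can be read on its own in this assay, where the two earlier compounds differed in more than one place. It shows that this saturated chain carbon, bound to an amine nitrogen and a saturated chain carbon, responds to substitution: one added methyl, just one heavy atom, turns neopentyl into 1,2,2-trimethylpropyl and moves the read-out beyond the scatter towards stronger inhibition. Nothing measured here explains why the methyl has this effect.

Going by these compounds, it remains open whether a larger group at the same carbon, such as ethyl or a longer chain, would move the number further, or whether a hydroxymethyl group would be accepted in place of the methyl. On these data alone, compound 3 is also drawn without a defined three-dimensional arrangement at the carbon carrying the new methyl, so the separate contributions of its two mirror-image forms remain unknown.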